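From 3-fluorophenyl to 2,4-dimethoxyphenyl in compound 2

The source may hold more compounds than are shown below. What is called first, only, known or untested is meant among the compounds shown, and "the series" means these compounds.

Compound 1 `COc1cc(/C=C/C(=O)/C(=C/c2cc(OC)c(OC)c(OC)c2)C(C)=O)cc(OC)c1OC` gives 530 nM
Compound 2 `COc1ccc(/C=C/C(=O)C(=Cc2cccc(F)c2)C(=O)/C=C/c2ccc(OC)c(OC)c2)cc1OC` gives 580 nM

In a functional assay on A549 cells (Homo sapiens) for inhibition, read by sulforhodamine B assay, with a stated time of 48 h (on this read-out lower numbers stand for stronger inhibition of growth and higher numbers for weaker inhibition of growth), compound 2 (at 580 nM) lies within the scatter of compound 1 (at 530 nM), so neither stands apart. Compound 3 `COc1ccc(C=C(C(=O)/C=C/c2ccc(OC)c(OC)c2)C(=O)/C=C/c2ccc(OC)c(OC)c2)c(OC)c1` carries 2,4-dimethoxyphenyl in place of 3-fluorophenyl on a double-bonded chain carbon bound to a double-bonded chain carbon. Going by the values given here, no measured pair shows this change, so the data offer no direct guide. The expected step (a 1.0-fold higher number from compound 2 to compound 3 (0.01 log units; within the scatter)) in this assay stays within the scatter, with no direction foreseen. For compound 3 the estimated value is 600 nM (expected range 200 nM to 1800 nM).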

Compound 3, concentration for 50% growth inhibition: 650 nM
Beside the measured number, compound 3's estimate is 1.1-fold (0.03 log units) below it; the range from low to high includes it.
By their numbers in this assay, from the lowest: compounds 1, 2 and 3 (each within the scatter of the next).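

In this assay, going by these compounds alone, 2,4-dimethoxyphenyl in place of 3-fluorophenyl on a double-bonded chain carbon bound to a double-bonded chain carbon gives a 1.1-fold higher number from compound 2 to compound 3 (0.05 log units; within the scatter) and is the first step read at this position. The two groups therefore cannot be told apart here, although they differ in heavy atoms and hydrogen-bond acceptors. No available evidence bears on this result. The compounds shown leave open whether this position tolerates any group, since both groups are substituted phenyl rings. An amine or a carboxylic acid at this place remains an untested question here.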